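The source may report more compounds than this note shows. Statements on the series, on what has been measured and on what is new or still open speak of the compounds shown alone.

Working notes on the series, read in a functional assay on PBMC cells (Homo sapiens) for cytotoxicity; a higher number here means a weaker inhibitor, a lower number a stronger inhibitor. Compound 1 (`Cc1cn([C@@H]2S[C@H](CO)[C@H]2CO)c(=O)[nH]c1=O`) gives > 100000 nM, which is a limit and not a number. Compound 2 (`Nc1ccn([C@@H]2S[C@H](CO)[C@H]2CO)c(=O)n1`) gives <= 1000 nM, also a limit. Compound 3 (`Nc1ncnc2c1ncn2[C@@H]1S[C@H](CO)[C@H]1CO`) gives > 100000 nM, again a limit. Compound 3 thus stands at the limit of > 100000 nM in this assay, at which 2 of the 3 values shown sit. Only compound 2 stands at the limit of <= 1000 nM in this assay, at which 1 of the 3 values shown sits.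

Compound 4 (`OC[C@H]1[C@H](n2cnc3c(O)ncnc32)S[C@@H]1CO`) carries hydroxy in place of amino on an aromatic carbon, relative to compound 3: hydroxy in place of amino on an aromatic carbon. Among the compounds with values here, no measured pair shows this change, and the limit for compound 3 gives no number to step from. In this assay no step beyond the scatter is expected, in either direction, and a further limit is the likeliest report. The expected change is a number no higher from compound 3 to compound 4 (the limit leaves the size open), an estimate that rests on the standing of compound 3 at > 100000 nM. The estimated value for compound 4 is 100000 nM, with an expected range from 30000 nM to 300000 nM.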

Compound 4, half-maximal inhibitory concentration: > 100000 nM
Compound 4 ended at the assay's limit; the forecaster's own chance of this, stated with the estimate: 85%; the middle value lies on the limit itself.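

In this assay compound 3 and compound 4 each end at a limit and not at a number, so no step can be read between them. The compounds shown leave open whether hydroxy in place of amino on an aromatic carbon changes the read-out at all.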